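Bromo for methyl on a pyrazoline series against gastric cells

The compounds below may be only part of what the source reports. "The series", "measured", "known", "first", "only" and "open" are said of these compounds alone.

Of the compounds shown here, two have been measured in a functional assay on BGC-823 cells (Homo sapiens) for inhibition, read by CCK-8 assay, with a stated time of 48 h; on this read-out lower numbers stand for stronger inhibition and higher numbers for weaker inhibition. Compound 1 `Brc1ccc(C2=NN(C3=NC(c4ccccc4)CS3)C(c3ccc4ccccc4c3)C2)cc1` gives 13000 nM in this assay. Compound 2 `Cc1ccc(C2=NN(C3=NC(c4ccccc4)CS3)C(c3cccc4ccccc34)C2)cc1` gives 13300 nM in this assay, a number that sits within the scatter of compound 1, so neither can be set above the other on what has been measured. Compound 3 `Brc1ccc(C2=NN(C3=NC(c4ccccc4)CS3)C(c3cccc4ccccc34)C2)cc1` has not yet been measured. It differs from compound 2 in one place: bromo in place of methyl on an aromatic carbon, a change read one bond further out as 4-methylphenyl to 4-bromophenyl. Within the data shown here, no step between measured compounds isolates this change, since compound 1 and compound 2 differ in two places at once. With the two measured numbers lying so close together, the step from compound 2 to compound 3 is expected to be a 1.0-fold lower number from compound 2 to compound 3 (0.01 log units; within the scatter), which is to say none beyond the scatter in either direction. Compound 3 is therefore estimated at 13000 nM in this assay, within a range from 5000 nM to 32000 nM.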

Compound 3, half-maximal inhibitory concentration: 17400 nM
The estimate for compound 3 lay 1.3-fold (0.13 log units) below the measured number; the range from low to high includes it.
By their numbers in this assay, from the lowest: compounds 1, 2 and 3 (each within the scatter of the next).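

In this assay, among these compounds, bromo in place of methyl on the aromatic carbon para to a large group gives a 1.3-fold higher number from compound 2 to compound 3 (0.12 log units; within the scatter) and so, for the first time, this exchange is seen on its own, with a naphthalen-1-yl group held constant. With bromo held constant, naphthalen-1-yl in place of naphthalen-2-yl gives a 1.3-fold higher number from compound 1 to compound 3 (0.13 log units; within the scatter) and so compound 3 joins compound 1 and compound 2 through two single changes, neither reaching beyond the scatter. Nothing available offers an explanation for either result. On these data alone, only methyl and bromo are seen at this position, so whether an amine or a carboxylic acid there would shift the number beyond the scatter remains open. Also open, as far as these compounds go, is whether the exchange of methyl for bromo reads the same alongside a naphthalen-2-yl group.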